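A few compounds are considered here, and "the series" means these few. Any claim that something is new, unique, unknown or untested is made for them only; others in the source may bear on it.

Compound 1 `N#Cc1c(N)nc(SCc2ccn[nH]2)c(C#N)c1-c1ccc(OCC2CC2)cc1` gives 84 nM in a functional assay on CHO cells for agonist activity at adenosine receptor A2b (Homo sapiens), read by AlphaScreen and cAMP accumulation; a lower number here means that less compound is needed, a higher number that more compound is needed for the effect.
Compound 2 `N#Cc1c(N)nc(SCc2cccc(C(N)=O)c2)c(C#N)c1-c1ccc(OCC2CC2)cc1` gives 12.7 nM in this assay.
Compound 3 `N#Cc1c(N)nc(SCc2cnc[nH]2)c(C#N)c1-c1ccc(OCC2CC2)cc1` gives 139 nM in this assay.

Compound 3 stands at the highest of the three numbers: the step of a 1.7-fold higher number from compound 1 to compound 3 (0.22 log units; within the scatter) stays within the scatter, whereas the step of an 11-fold higher number from compound 2 to compound 3 (1.04 log units; beyond the scatter) is large. Compound 4 `N#Cc1c(N)nc(SCc2ncn[nH]2)c(C#N)c1-c1ccc(OCC2CC2)cc1` carries the change (1H-1,2,4-triazol-5-yl in place of 1H-imidazol-5-yl on a saturated chain carbon bound to a sulfur). Going by the values given here, the closest precedent is the swap of one five-membered ring for another, a 1.7-fold higher number from compound 1 to compound 3 (0.22 log units; within the scatter), which stayed within the scatter; the large steps of a 6.6-fold lower number from compound 1 to compound 2 (0.82 log units; beyond the scatter) and an 11-fold higher number from compound 2 to compound 3 (1.04 log units; beyond the scatter) involve the carbamoylphenyl group and do not bear directly on this ring swap. The expectation is therefore a step of a 1.2-fold lower number from compound 3 to compound 4 (0.06 log units; within the scatter) in this assay that does not exceed the scatter. Compound 4 is estimated at 120 nM, between 50 nM and 300 nM.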

Compound 4, half-maximal effective concentration: 51 nM
Beside the measured number, compound 4's estimate is 2.4-fold (0.37 log units) above it; the range from low to high includes it.
By their numbers in this assay, from the lowest: compound 2; then compounds 4, 1 and 3 (each within the scatter of the next, the first and the last beyond it).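

Exchanging one five-membered ring for another at this place is not always a silent change: the 1H-1,2,4-triazol-5-yl group gives a 2.7-fold lower number from compound 3 to compound 4 (0.44 log units; beyond the scatter), yet a 1.6-fold lower number from compound 1 to compound 4 (0.22 log units; within the scatter), so it cannot be told apart from the 1H-pyrazol-5-yl group. It also does not match the 3-carbamoylphenyl group, with a 4.0-fold higher number from compound 2 to compound 4 (0.60 log units; beyond the scatter). Nothing measured here gives a reason for these steps. Still open, from the compounds shown here alone, is how a 1H-1,2,4-triazol-5-yl ring carrying an amine or a carboxylic acid would compare, or one attached through a longer chain.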